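Lengthening the Nitrogen Chain of a Writhing-Test Analgesic

This account rests on a few compounds, and the source may have more. Where it says the series, first, only, none or still open, it means among the compounds named here.

Going by the values given here, compound 1, with the structure `CCCn1nc2oc(=O)cc(C)c2c1C`, is the only member of this small set to give a measured number. In a functional assay on the whole organism with Mus musculus as the target, in the writhing test (a lower number here means that less compound is needed, a higher number that more compound is needed for the effect), compound 1 gives 72.6 mg/kg. Compound 2, `Cc1cc(=O)oc2c1c(CC(=O)O)nn2C`, reaches only a limit of the assay: in this assay compound 2 gives > 100 mg/kg. Compound 3, `CCCCn1nc(C)c2c(C)cc(=O)oc21`, likewise stops at a limit, since in this assay compound 3 gives > 100 mg/kg. Compound 1 therefore stands alone with a real value, while the limit of > 100 mg/kg in this assay, at which 2 of the 3 values shown sit, describes where the other two sit.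

Compound 4, `CCCCCn1nc2oc(=O)cc(C)c2c1C`, has not yet been tested. It differs from compound 1 by a single change: ethyl in place of hydrogen on a saturated chain carbon, three bonds along the chain from an aromatic nitrogen. Among the compounds with values here, no step between two measured compounds in this set shows what such a lengthening of the chain on the ring nitrogen does, so there is no measured guide for the direction of the step.

With that in mind, only a modest change is expected, roughly within the usual scatter, and the step expected from compound 1 to compound 4 in this assay is a 1.2-fold higher number from compound 1 to compound 4 (0.09 log units; within the scatter). For compound 4 the expected value in this assay is 90 mg/kg, with a plausible range from 40 mg/kg to 200 mg/kg, and a real chance that only a limit is reported.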

Compound 4, dose for half-maximal effect: 60.6 mg/kg
Beside the measured number, compound 4's estimate is 1.5-fold (0.17 log units) above it; the range from low to high includes it.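

In this assay, going by these compounds alone, the first step that can be read at this position, propyl to pentyl on the aromatic nitrogen, is a 1.2-fold lower number from compound 1 to compound 4 (0.08 log units; within the scatter). The chain can therefore grow by an ethyl group at its far end without a change that this assay can tell apart from ordinary repeat-to-repeat variation, so the two compounds count as equal here. Compound 4 also gives a real number rather than a limit, which makes it the second compound in the set with a value that can be compared, and that is useful given how many entries stop at the top of the assay: the limit of > 100 mg/kg in this assay, at which 2 of the 4 values shown sit.

Within the data shown here, compounds 2 and 3 differ from compound 1 in more than one place, so no step to either can be read, and this single step cannot show a trend along the chain. From the compounds shown here alone, it remains open whether a much longer chain, such as decyl, or a chain ending in an amine, would keep this level of effect or shift it clearly beyond the scatter.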